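This account rests on a few compounds, and the source may have more. Where it says the series, first, only, none or still open, it means among the compounds named here.

Measured so far:
compound 1 `CC1OC(OC2CCCCC2OCCCCCCCCCCC(C(=O)O)C(=O)O)C(O)C(O)C1O` — in a functional assay on HL-60 cells (Homo sapiens) for inhibition (on this read-out lower numbers stand for stronger inhibition and higher numbers for weaker inhibition), compound 1 reached only the limit of the assay, > 5000000 nM.
compound 2 `CC1OC(OC2CCCCC2OC(=O)NCCC(C(=O)O)C(=O)O)C(O)C(O)C1O` — in this assay compound 2 gives 3400000 nM.

Compound 2 thus holds the only number shown; the other value sits at the limit of > 5000000 nM in this assay, at which 1 of the 2 values shown sits. Compound 3 `CC1OC(OC2CCCCC2OC(=O)NCCCCC(C(=O)O)C(=O)O)C(O)C(O)C1O` differs from compound 2 by 3,3-dicarboxypropyl in place of dicarboxymethyl on a saturated chain carbon, two bonds along the chain from an amide-type nitrogen. Going by the values given here, with no step between measured compounds to lean on, the expectation in this assay is a step within the usual scatter, in no particular direction. Compound 3 is therefore estimated at 3500000 nM, somewhere from 1000000 nM to 12000000 nM, which means an expected 1.0-fold higher number from compound 2 to compound 3 (0.01 log units; within the scatter).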

Compound 3, half-maximal inhibitory concentration: 4000000 nM
Compound 3: the middle estimate sits 1.1-fold (0.06 log units) below what was measured, and the stated range covers the measured number.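

In this assay, 3,3-dicarboxypropyl in place of dicarboxymethyl gives a 1.2-fold higher number from compound 2 to compound 3 (0.07 log units; within the scatter) on this saturated chain carbon. At this position, then, the longer group changes the read-out by no more than the usual scatter, and the two numbers cannot be told apart. Nothing measured here explains this result.

Going by these compounds, whether a still longer chain would give a clearly lower number remains open. So does the effect of ending the chain in an amine or a single carboxylic acid instead of the two carboxylic acids.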